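Swapping the Aryl Group on the Carbonyl Carbon

This account rests on a few compounds, and the source may have more. Where it says the series, first, only, none or still open, it means among the compounds named here.

In a functional assay on Ehrlich cells (Mus musculus) for cytotoxicity, read by MTT assay, with a stated time of 48 h (a higher number here means a weaker inhibitor, a lower number a stronger inhibitor), the three measured compounds give the following numbers:
compound 1 `COc1ccc(C(=O)c2cc(C)ccc2OCC(=O)NNC(=O)c2cc3ccccc3oc2=O)cc1`: 38400 nM
compound 2 `Cc1ccc(OCC(=O)NNC(=O)c2cc3ccccc3oc2=O)c(C(=O)c2cccc(Cl)c2)c1`: 64900 nM
compound 3 `Cc1ccc(OCC(=O)NNC(=O)c2cc3ccccc3oc2=O)c(C(=O)c2ccccc2Cl)c1`: 45200 nM

Compound 3 gives the middle number of the three. Its nearest neighbour is compound 1 and its furthest is compound 2, and both gaps fall within the scatter, so the three compounds cannot be told apart on these numbers.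

The next compound, compound 4 `Cc1ccc(OCC(=O)NNC(=O)c2cc3ccccc3oc2=O)c(C(=O)c2ccc(F)cc2)c1`, differs from compound 3 in one place: 4-fluorophenyl in place of 2-chlorophenyl on a carbonyl carbon. Among the compounds with values here, every measured step so far changes the same aryl group on the same carbonyl carbon. The step of a 1.7-fold higher number from compound 1 to compound 2 (0.23 log units; within the scatter), the step of a 1.2-fold higher number from compound 1 to compound 3 (0.07 log units; within the scatter) and the step of a 1.4-fold lower number from compound 2 to compound 3 (0.16 log units; within the scatter) all stay within the scatter. Nothing in the measured set therefore points to a step beyond the scatter when a 4-fluorophenyl replaces the 2-chlorophenyl, and the expectation for compound 4 is a step of about a 1.0-fold higher number from compound 3 to compound 4 (0.01 log units; within the scatter), meaning no real change in either direction.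

On that basis compound 4 is estimated at 46000 nM in this assay, with a range from 24000 nM to 90000 nM that covers the spread of the three measured compounds and the usual scatter of the measurement.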

Compound 4, half-maximal inhibitory concentration: 39700 nM
Beside the measured number, compound 4's estimate is 1.2-fold (0.06 log units) above it; the range from low to high includes it.
By their numbers in this assay, from the lowest: compounds 1, 4, 3 and 2 (each within the scatter of the next).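

In this assay the 4-fluorophenyl group brings a fourth aryl group and the first fluorine to this carbonyl carbon, and neither the exchange for the 2-chlorophenyl group (a 1.1-fold lower number from compound 3 to compound 4 (0.06 log units; within the scatter)) nor the exchange for the 3-chlorophenyl group (a 1.6-fold lower number from compound 2 to compound 4 (0.21 log units; within the scatter)) leaves the scatter. The new compound also gives a direct comparison of fluoro with methoxy on the aromatic carbon of this ring (a 1.0-fold higher number from compound 1 to compound 4 (0.01 log units; within the scatter)), and that step stays within the scatter as well, so the four compounds cannot be told apart and the position has so far shown no measurable response to these aryl groups. Nothing available here explains this absence of a difference.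

As far as these compounds go, all four compounds carry a singly substituted phenyl group on this carbonyl carbon, so it remains open whether any group there can move the number beyond the scatter, for instance a phenyl ring bearing an amine or a carboxylic acid, or a longer chain in place of the ring. The shown compounds also leave open what a change elsewhere on the shared core would do, as every step here stays at this one position.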